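Aryl thioether exchange in a benzamide series

The source may hold more compounds than are shown below. What is called first, only, known or untested is meant among the compounds shown, and "the series" means these compounds.

Measured in a functional assay on HeLa cells (Homo sapiens) for inhibition, read by CCK-8 assay, with a stated time of 72 h, tested at 2 uM; a lower number here means less inhibition of growth, a higher number more inhibition of growth at the concentration tested:
compound 1 `Nc1ccccc1NC(=O)c1ccc(CSc2ccc(Br)cc2)cc1` gives 18.8%
compound 2 `Nc1ccccc1NC(=O)c1ccc(CSc2ccc(C(F)(F)F)cn2)cc1` gives 11.5%

Compound 1 carries the higher of the two numbers, but its gap to compound 2 lies within the usual scatter, so the two cannot be ranked against each other. For the measured compounds named here, no pair among the measured compounds differs in a single place, so no measured step is available to guide the next compound.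

Compound 3 `Cc1cc(C)cc(SCc2ccc(C(=O)Nc3ccccc3N)cc2)c1` has not yet been measured. It differs from compound 1 as follows: 3,5-dimethylphenyl in place of 4-bromophenyl on a sulfur. Both measured compounds keep the same core and vary only the group on the sulfur, and their values in this assay sit close together. On that basis no step beyond the scatter is expected for compound 3 in this assay; the expected step is a number 1.8 percentage points lower from compound 1 to compound 3 (within the scatter). Compound 3 is therefore estimated at 17%, with a range from 5% to 30%.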

Compound 3, percent growth inhibition at one concentration: 40.2%
Compound 3: middle estimate off by 23.2 percentage points, on the low side; the measured number lies above the stated range.
By their numbers in this assay, from the lowest: compounds 2 and 1 (each within the scatter of the next); then compound 3.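

Within this assay the exchange of 4-bromophenyl for 3,5-dimethylphenyl on a sulfur gives a number 21.4 percentage points higher from compound 1 to compound 3 (beyond the scatter). For the compounds shown here, this is the only readable step so far, and it shows that the group on this sulfur can move growth inhibition beyond the scatter while the shared core stays the same. The step occurs with a carbon-only aromatic ring on both sides, no hydrogen-bond donors or acceptors in either group and no net charge, and nothing available bears on why it occurs.

The compounds shown leave open whether the step follows the loss of the bromine or the arrival of the two methyl groups. Also open, as far as these compounds go, is whether a 3,5-dichlorophenyl or 3,5-dimethoxyphenyl group on the same sulfur would keep the step.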